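Trimming a Benzyl Group to Ethyl: What Compound 4 Might Give

This account rests on a few compounds, and the source may have more. Where it says the series, first, only, none or still open, it means among the compounds named here.

Of the compounds shown here, three sharing one core have been tested in a functional assay on L1210 cells (Mus musculus) for cytotoxicity, read by cell counting, with a stated time of 2 days; on this read-out lower numbers stand for stronger inhibition and higher numbers for weaker inhibition. Compound 1 `C=C(Br)C(=O)Nc1ccc(/C=C2\SC(=O)N(Cc3cccc(F)c3)C2=O)cc1` gives 1200 nM, compound 2 `Nc1ccc(/C=C2\SC(=O)N(Cc3ccc(Cl)cc3)C2=O)cc1` gives 37000 nM, and compound 3 `C=C(Br)C(=O)Nc1ccc(/C=C2\SC(=O)N(Cc3ccc(C)cc3)C2=O)cc1` gives 3400 nM, the second highest of the three numbers. For the measured compounds named here, the only single-place step among them, a 2.8-fold higher number from compound 1 to compound 3 (0.45 log units; beyond the scatter), is modest. Compound 4 `C=C(Br)C(=O)Nc1ccc(/C=C2\SC(=O)N(CC)C2=O)cc1` differs from compound 3 by methyl in place of 4-methylphenyl on a saturated chain carbon bound to an amide-type nitrogen in a ring. Going by the values given here, no measured step replaces an aromatic group with a short chain, so the precedent is indirect; the one step available, a 2.8-fold higher number from compound 1 to compound 3 (0.45 log units; beyond the scatter), shows that altering this group shifts the number only modestly. A modest weakening is therefore expected, a 2.1-fold higher number from compound 3 to compound 4 (0.31 log units; beyond the scatter). Compound 4 is estimated at 7000 nM, with a range from 2500 nM to 20000 nM.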

Compound 4, half-maximal inhibitory concentration: 500 nM
Compound 4: the middle estimate sits 14-fold (1.15 log units) above what was measured; measured number outside the range, below it.
By their numbers in this assay, from the lowest: compound 4; then compound 1; then compound 3; then compound 2.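

Trimming 4-methylbenzyl to ethyl gives a 6.8-fold lower number from compound 3 to compound 4 (0.83 log units; beyond the scatter), and ethyl also compares well with the 3-fluorobenzyl group, with a 2.4-fold lower number from compound 1 to compound 4 (0.38 log units; beyond the scatter). Among these compounds, then, an aromatic ring at this position is not needed for strong inhibition, and the smaller ethyl group gives the lowest number of the series. Nothing measured here explains why the smaller group gives the lower number.

From the compounds shown here alone, whether a propyl or butyl chain would hold this gain remains open. So does the effect of ending the ethyl chain in an amine or a carboxylic acid.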